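Methoxy in Place of Bromo: Compound 1 to Compound 4

This account rests on a few compounds, and the source may have more. Where it says the series, first, only, none or still open, it means among the compounds named here.

Of the compounds shown here, three have numbers so far in a functional assay on A-375 cells (Homo sapiens) for inhibition, read by CCK-8 assay, with a stated time of 72 h, tested at 2 uM; on this read-out higher numbers stand for more inhibition of growth at the one concentration tested and lower numbers for less inhibition of growth. Compound 1 `Nc1ccccc1NC(=O)c1ccc(CSc2ccc(Br)cc2)cc1` gives 4.35% and stands second highest of the three. Among the measured compounds shown here, compound 3 `Nc1ccccc1NC(=O)c1ccc(CSc2ccc(C(F)(F)F)cn2)cc1` gives 4.3%, a number within the scatter of the one for compound 1, so the two cannot be told apart. For the measured compounds named here, compound 2 `Nc1ccccc1NC(=O)/C=C/c1ccc(CSc2ccc(F)cc2)cc1` gives 28.8%, which stands beyond the scatter above compound 1 and is the only number in the set that does.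

Compound 4 `COc1ccc(SCc2ccc(C(=O)Nc3ccccc3N)cc2)cc1` has not yet been measured in this assay. It differs from compound 1 in one place: methoxy in place of bromo on an aromatic carbon. Going by the values given here, no measured pair in the set carries this same change, so the data give no step to lean on. Compound 1 at 4.35% and compound 3 at 4.3% both sit low, and nothing here points to either direction for the new substituent. The expected step is therefore a number 1.7 percentage points higher from compound 1 to compound 4 (within the scatter), not beyond the scatter. Compound 4 is estimated at 6%, with a range from -6% to 20%.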

Compound 4, percent growth inhibition at one concentration: 10.2%
Beside the measured number, compound 4's estimate is 4.2 percentage points below it; the range from low to high includes it.
By their numbers in this assay, from the lowest: compounds 3, 1 and 4 (each within the scatter of the next); then compound 2.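

In this assay the position para to a large group now has its first readable step, with methoxy in place of bromo giving a number 5.9 percentage points higher from compound 1 to compound 4 (within the scatter) on the shared core. This one pair therefore shows no separation between the 4-bromophenyl and 4-methoxyphenyl compounds, even though a hydrogen-bond acceptor enters where bromine leaves. No evidence on hand bears on this result.

From the compounds shown here alone, whether another group at this position, such as an amine, a carboxylic acid or a longer alkoxy chain, would move the number beyond the scatter stays open. Compound 2 differs from compound 1, compound 3 and compound 4 in more than one place, so the steps to it cannot be read and its higher number is tied to no single change.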